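A few compounds are considered here, and "the series" means these few. Any claim that something is new, unique, unknown or untested is made for them only; others in the source may bear on it.

Of the compounds shown here, three sharing one core have been tested in a functional assay on MDA-MB-231 cells (Homo sapiens) for antiproliferative activity, read by MTT assay, with stated times of 72 h and 4 h; on this read-out lower numbers stand for stronger inhibition and higher numbers for weaker inhibition. Compound 1 `O=C(Nc1ccc(Cl)c(-c2nnc3c(Cl)cccn23)c1)c1ccccn1` carries a pyridin-2-yl group on the carbonyl carbon of its amide, and it is the only one of the three to return an actual number: in this assay compound 1 gives 92000 nM. Compound 2 `O=C(Nc1ccc(Cl)c(-c2nnc3c(Cl)cccn23)c1)c1ccc(Cl)cc1` carries 4-chlorophenyl in that place instead. For compound 2 this assay reports only a limit, > 100000 nM. Compound 3 `O=C(Nc1ccc(Cl)c(-c2nnc3c(Cl)cccn23)c1)c1ccc(C(F)(F)F)cc1F` carries a phenyl bearing a trifluoromethyl group and a fluorine. For compound 3 this assay likewise reports only a limit, > 100000 nM. Among the measured compounds shown here, the single measured step, an at least 1.0-fold higher number from compound 1 to compound 2 (0.03 log units; that floor lies within the scatter), is therefore only a floor and not a true size, because the limit of > 100000 nM in this assay, at which 2 of the 3 values shown sit, is where the value of compound 2 sits.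

Compound 4 `O=C(Nc1ccc(Cl)c(-c2nnc3c(Cl)cccn23)c1)c1cccc(Cl)c1` differs from compound 1 by 3-chlorophenyl in place of pyridin-2-yl on a carbonyl carbon. The step that bears on it, an at least 1.0-fold higher number from compound 1 to compound 2 (0.03 log units; that floor lies within the scatter), also swaps the pyridin-2-yl for a chlorine-bearing phenyl and reached no more than the limit. No gain is therefore expected from compound 1 to compound 4, and the expected step is a 1.2-fold higher number from compound 1 to compound 4 (0.08 log units; within the scatter). The estimate for compound 4 in this assay is 110000 nM, with a range from 50000 nM to 250000 nM, and the result may well come back as a limit rather than a number.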

Compound 4, half-maximal inhibitory concentration: 66100 nM
Compound 4: the middle estimate sits 1.7-fold (0.22 log units) above what was measured; the range from low to high includes it.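

In this assay, a chlorine-bearing phenyl on this carbonyl carbon does not automatically put a compound at the limit of the assay: compound 4, with its 3-chlorophenyl group, returns an actual number, which compound 2 and compound 3 did not. Exchanging pyridin-2-yl for 3-chlorophenyl gives a 1.4-fold lower number from compound 1 to compound 4 (0.14 log units; within the scatter), so the ring nitrogen of pyridin-2-yl makes no difference that this assay can resolve. Exchanging 4-chlorophenyl for 3-chlorophenyl gives an at least 1.5-fold lower number from compound 2 to compound 4 (0.17 log units; that floor lies within the scatter), and the true size of that step remains unknown because it is only a floor set by a limit: the limit of > 100000 nM in this assay, at which 2 of the 4 values shown sit.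

Every compound shown carries an aromatic ring on this carbonyl carbon, and every result lies close to the top of the range the assay can report, so it remains open whether any change at this position can bring the number down well beyond the scatter. It is also unknown how a phenyl bearing a methoxy group, or an amine or a carboxylic acid attached to the ring, would read in this assay.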